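Swapping Methoxy for Trifluoromethoxy on a Histamine Agonist

This account rests on a few compounds, and the source may have more. Where it says the series, first, only, none or still open, it means among the compounds named here.

The measurements come from a functional assay on Right cardiac atrium for agonist activity at histamine H2 receptor (Cavia porcellus), with a stated time of 30 min, in the presence of a further agent that is not named here; a lower number here means that less compound is needed, a higher number that more compound is needed for the effect. Compound 1, `COc1ccc(C(C)NC(=O)/N=C(\N)NCCCc2sc(N)nc2C)cc1`, gives 38 nM in this assay, the lower of the two numbers recorded so far. Compound 2, `Cc1nc(N)sc1CCCN/C(N)=N/C(=S)N[C@H](C)c1ccccc1`, gives 89.1 nM in this assay, a higher number than compound 1 by more than the usual scatter; the two compounds differ in several places at once, so no single change can be read from that pair.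

Compound 3, `Cc1nc(N)sc1CCCN/C(N)=N/C(=O)NC(C)c1ccc(OC(F)(F)F)cc1`, has not yet been measured. It differs from compound 1 in one place: trifluoromethyl in place of methyl on an oxygen on an aromatic ring. Among the measured compounds shown here, no measured pair shows this change, so nothing in the data says which way it will move. The expected step from compound 1 to compound 3 is a 1.3-fold higher number from compound 1 to compound 3 (0.12 log units; within the scatter), a move not beyond the scatter. Compound 3 is therefore estimated at 50 nM, within a range from 15 nM to 160 nM.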

Compound 3, half-maximal effective concentration: 724 nM
The estimate for compound 3 lay 14-fold (1.16 log units) below the measured number; measured number outside the range, above it.
By their numbers in this assay, from the lowest: compound 1; then compound 2; then compound 3.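

In this assay, the group on this oxygen turns out to matter a great deal: methoxy to trifluoromethoxy gives a 19-fold higher number from compound 1 to compound 3 (1.28 log units; beyond the scatter), so far more compound is needed for the same effect. This is the only single-place step among the compounds shown, and it moves the number well beyond the scatter even though neither group carries a hydrogen-bond donor, a hydrogen-bond acceptor or a net charge. Nothing available here explains why the step is so large.

From the compounds shown here alone, it remains open whether the rise follows from the fluorine atoms themselves or from the greater number of heavy atoms, and an ethoxy or difluoromethoxy group at the same place would help separate the two. A single pair also cannot show whether the same change would have a similar effect on another core.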